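From Methyl to Trifluoromethyl: Compound 3 to Compound 4

This account rests on a few compounds, and the source may have more. Where it says the series, first, only, none or still open, it means among the compounds named here.

Compound 1 `O=C(NCc1ccccc1Cl)N1C(=O)c2ccccc2S1(=O)=O` gives > 166 h in a physicochemical assay for pharmacokinetics (a higher number here means that the compound lasts longer, a lower number that the compound disappears faster), a limit of the assay rather than a number.
Compound 2 `O=C(NCc1ccccc1)N1C(=O)c2ccccc2S1(=O)=O` gives > 166 h in this assay, again only a limit.
Compound 3 `Cc1ccccc1CNC(=O)N1C(=O)c2ccccc2S1(=O)=O` gives > 166 h in this assay, again only a limit.

All three measured values therefore sit at the same limit, and the three steps among them cannot be read: a step that the two limits leave unreadable from compound 1 to compound 2, a step that the two limits leave unreadable from compound 1 to compound 3 and a step that the two limits leave unreadable from compound 2 to compound 3 all remain of unknown size. Compound 3 thus stands where compound 1 and compound 2 also stand, at the upper edge of what this assay reports, because of the limit of > 166 h in this assay, at which 3 of the 3 values shown sit.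

Compound 4 `O=C(NCc1ccccc1C(F)(F)F)N1C(=O)c2ccccc2S1(=O)=O` is the next compound to be measured in this assay. It differs from compound 3 in one place: trifluoromethyl in place of methyl on an aromatic carbon. The measured steps that bear on this change, those from compound 1 to compound 2, from compound 1 to compound 3 and from compound 2 to compound 3, all swap a group at this same position, and none of them shows a readable size, so no direction can be drawn from them. For the measured compounds named here, the most that can be said is that every change at this position so far has left the compound at the limit of this assay.

Compound 4 is accordingly expected to give a half-life near 200 h, within a range of 100 h to 400 h, and most likely again only a limit. The estimated step from compound 3 to compound 4 is thus a step that the limit leaves unreadable from compound 3 to compound 4, with a real chance that the assay reports no number at all.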

Compound 4, half-life: > 166 h
Compound 4 gave a limit, no number; the forecaster's own chance of this, stated with the estimate: 75%; the middle value does not contradict the limit.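

In this assay compound 4 gives > 166 h, again only a limit. The steps joining compound 4 to compound 1, compound 2 and compound 3 therefore cannot be read, and all four compounds sit together: the limit of > 166 h in this assay, at which 4 of the 4 values shown sit. The compounds shown leave open what the actual half-lives are and whether swapping these groups changes them at all.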